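Dithiocarbamate benzamides: pyridinylmethyl to fluorophenyl on piperazine

The source may hold more compounds than are shown below. What is called first, only, known or untested is meant among the compounds shown, and "the series" means these compounds.

Two compounds of the series carry a measured value. Compound 1 `CN(Cc1cccnc1)C(=S)SCc1ccc(C(=O)Nc2ccccc2N)cc1` gives 45.9% in a functional assay on MGC-803 cells (Homo sapiens) for antiproliferative activity, read by CCK-8 assay, with a stated time of 72 h, tested at 2 uM; on this read-out lower numbers stand for a weaker effect and higher numbers for a stronger effect at the one concentration tested. Compound 2 `Nc1ccccc1NC(=O)c1ccc(CSC(=S)N2CCN(Cc3ccncc3)CC2)cc1` gives 18.4% in the same read-out, the lowest of the two numbers; compound 1 lies higher by an amount beyond the usual scatter. Within the data shown here, no pair of measured compounds differs in a single place, so no single-change step is available to lean on.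

Compound 3 `Nc1ccccc1NC(=O)c1ccc(CSC(=S)N2CCN(c3ccccc3F)CC2)cc1` has not been measured. Relative to compound 2 the change is 2-fluorophenyl in place of (pyridin-4-yl)methyl on an amine nitrogen in a ring. Among the measured compounds shown here, no measured step of this kind exists, so the expectation for compound 3 rests on the two values alone and on the change itself. With compound 2 at 18.4% standing at the bottom of the range seen so far, a step upward of moderate size is expected for compound 3, though a result within the scatter of compound 2 cannot be excluded. The estimated step from compound 2 to compound 3 is a number 11.6 percentage points higher from compound 2 to compound 3 (beyond the scatter). Compound 3 is estimated at 30%, with a range from 10% to 55%.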

Compound 3, a percentage reported as inhibition, at one concentration (the size of the read-out at that concentration, not a potency): 33.7%
The estimate for compound 3 lay 3.7 percentage points below the measured number, within the range that was stated.
By their numbers in this assay, from the lowest: compound 2; then compound 3; then compound 1.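

In this assay, the series now has its first single-change step, at the amine nitrogen in the six-membered non-aromatic ring with 2 nitrogen: the step reads a number 15.3 percentage points higher from compound 2 to compound 3 (beyond the scatter) and shows that the read-out responds to the group placed on this nitrogen. The change is not one of heavy-atom count, since (pyridin-4-yl)methyl and 2-fluorophenyl have the same number of heavy atoms and each holds one six-membered aromatic ring; what differs is that the ring nitrogen, the hydrogen-bond acceptor and the methyl link leave while a fluorine enters on a carbon-only ring attached directly to the amine nitrogen. No measurement on hand bears on why the read-out moves with this change.

This one step changes those features together, leaving open whether the fluorine, the loss of the pyridine ring nitrogen or the loss of the methyl link accounts for the rise. Plain phenyl, benzyl and 4-fluorophenyl on the same nitrogen remain open as the groups that would tell these features apart.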